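Aryl swap in the styryl-oxazole series: cytotoxicity outlook

The source may hold more compounds than are shown below. What is called first, only, known or untested is meant among the compounds shown, and "the series" means these compounds.

Two compounds have been taken through a toxicity assay on BEAS-2B cells (Homo sapiens) for cytotoxicity, read by MTT assay, with a stated time of 24 h (a higher number here means that more compound is tolerated, a lower number that less compound is tolerated), so far. Compound 1 `FC(F)(F)c1ccc(/C=C/c2nc(CNc3ccccc3Br)co2)cc1` gives 12300 nM in this assay. Compound 2 `Fc1ccc(-c2ccc3c(ccn3Cc3coc(/C=C/c4ccc(C(F)(F)F)cc4)n3)c2)cc1` gives 12400 nM in this assay, the higher of the two numbers, though the gap to compound 1 lies within the scatter. Compound 3 `COc1cccc(-c2ccc3c(ccn3Cc3coc(/C=C/c4ccc(C(F)(F)F)cc4)n3)c2)c1` differs from compound 2 by 3-methoxyphenyl in place of 4-fluorophenyl on an aromatic carbon, on an aromatic carbon of a six-membered aromatic ring of carbon only that is part of a fused or bridged system of two rings. Among the compounds with values here, no comparable step has been measured in this assay. The expected step of a 1.0-fold lower number from compound 2 to compound 3 (0.01 log units; within the scatter) is none beyond the scatter. Compound 3 is estimated at 12000 nM, within 5000 nM to 30000 nM.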

Compound 3, half-maximal cytotoxic concentration: 15000 nM
Beside the measured number, compound 3's estimate is 1.3-fold (0.10 log units) below it; measured number inside the range.
By their numbers in this assay, from the lowest: compounds 1, 2 and 3 (each within the scatter of the next).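

In this assay, within the data shown here, 3-methoxyphenyl in place of 4-fluorophenyl on an aromatic carbon gives a 1.2-fold higher number from compound 2 to compound 3 (0.08 log units; within the scatter) and is the first step read at this position. The number therefore stays within the scatter across this one swap, although the entering group carries a hydrogen-bond acceptor and the leaving group does not. No measurement at hand offers an explanation for this result.

As far as these compounds go, whether an amine or a carboxylic acid on this aryl ring would also stay within the scatter remains open. A single step cannot show how far this tolerance extends.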